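Cyclopropylcarbonyl in place of furoyl on the shared core

The compounds below may be only part of what the source reports. "The series", "measured", "known", "first", "only" and "open" are said of these compounds alone.

Measured so far:
compound 1, `Cc1cccc(Cn2c(OC3CCN(C(=O)c4ccco4)CC3)nc3ccccc32)c1`, 68.3%
compound 2, `CC(C)CCn1c(OC2CCN(C(=O)c3ccco3)CC2)nc2ccccc21`, 30.8%
compound 3, `O=C(C1CC1)N1CCN(Cc2nc3ccccc3n2Cc2ccccc2)CC1`, 23.9%

The three compounds were tested in an assay on isolated protein for inhibition of aldehyde dehydrogenase 1A1 (Homo sapiens), read by spectrophotometry, tested at 10 uM; a higher number here means more inhibition at the concentration tested (going by the name of the read-out), a lower number less inhibition. Compound 1 gives the highest number, 68.3%. Going by the values given here, compound 2 stands second of the three: the only single-point step measured, a number 37.5 percentage points lower from compound 1 to compound 2 (beyond the scatter), separates it from compound 1, while compound 3, with 23.9%, lies within the scatter of compound 2, so no order between those two can be stated.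

Compound 4, `CC(C)CCn1c(OC2CCN(C(=O)C3CC3)CC2)nc2ccccc21`, has not yet been measured. It differs from compound 2 in one place: cyclopropyl in place of furan-2-yl on a carbonyl carbon. Among the compounds with values here, no measured step concerns this change; the one step on record alters a different part of the molecule. Compound 3 does carry a cyclopropylcarbonyl group, but it differs from compound 2 in more than one place, so the value of compound 3, 23.9%, can only be read as a loose hint that a cyclopropylcarbonyl compound need not fall far below compound 2.

With nothing measured on this change, compound 4 is expected to show no step beyond the scatter, a number 2.8 percentage points lower from compound 2 to compound 4 (within the scatter). Compound 4 is therefore estimated at 28% in this assay, with a range of 8% to 48%.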

Compound 4, a percentage reported as inhibition, at one concentration (the size of the read-out at that concentration, not a potency): 56.4%
For compound 4 the middle estimate is 28.4 percentage points below the measured one; measured number outside the range, above it.
By their numbers in this assay, from the lowest: compounds 3 and 2 (each within the scatter of the next); then compound 4; then compound 1.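

In this assay, going by these compounds alone, the group on the carbonyl carbon proves to be a place where a single change registers, with a number 25.6 percentage points higher from compound 2 to compound 4 (beyond the scatter); until now, the only step on record concerned the group on the aromatic nitrogen. With isobutyl held constant in compound 2 and compound 4, furan-2-yl is not needed for this inhibition, since cyclopropyl, with fewer heavy atoms and no hydrogen-bond acceptor in place of the one counted for furan-2-yl, gives the higher number. No evidence is available that explains why this change raises the number.

The compounds shown leave open whether the same gain would appear with 3-methylphenyl in place of isobutyl, as the change has been read on the isobutyl compounds alone. They also leave open whether the gain is particular to cyclopropyl or would extend to other groups on the carbonyl carbon, such as cyclobutyl or a tert-butyl group, and so how much room this place offers.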